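Methoxy on the indole benzo ring of compound 1

The source may hold more compounds than are shown below. What is called first, only, known or untested is meant among the compounds shown, and "the series" means these compounds.

Measured compounds:
compound 1 `COc1cc(/C(Cl)=C/C=C(\C#N)C(=O)c2c[nH]c3ccccc23)cc(OC)c1OC` — 59.1%
compound 2 `COc1cc(/C(Cl)=C/C=C(\C#N)C(=O)c2c(C)[nH]c3ccccc23)cc(OC)c1OC` — 58.2%

Two compounds of the series carry numbers in a functional assay for inhibition, with a stated time of 5 min, tested at 1 mM; on this read-out lower numbers stand for less inhibition and higher numbers for more inhibition at the one concentration tested (going by the name of the read-out). In this assay compound 1 gives 59.1%, and compound 2 gives 58.2%. Among the compounds with values here, the one step between them, a number 0.9 percentage points lower from compound 1 to compound 2 (within the scatter), is a methyl in place of hydrogen on an aromatic carbon; compound 1 and compound 2 therefore lie within the scatter of each other, and neither can be called the stronger.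

Compound 3 `COc1ccc2[nH]cc(C(=O)/C(C#N)=C/C=C(\Cl)c3cc(OC)c(OC)c(OC)c3)c2c1` has not yet been measured in this assay. It differs from compound 1 by methoxy in place of hydrogen on an aromatic carbon. Within the data shown here, no measured step substitutes a group at that place; the only step known, from compound 1 to compound 2, sits elsewhere on the shared core and stayed within the scatter. With nothing else to lean on, a small substituent change on the aromatic part of the core is expected to leave the number roughly where compound 1 stands, so the expected step is a number 2.1 percentage points lower from compound 1 to compound 3 (within the scatter), none beyond the scatter. Compound 3 is thus estimated at 57%, with a range from 40% to 72%.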

Compound 3, a percentage reported as inhibition, at one concentration (the size of the read-out at that concentration, not a potency): 50%
Beside the measured number, compound 3's estimate is 7 percentage points above it; measured number inside the range.
By their numbers in this assay, from the lowest: compounds 3, 2 and 1 (each within the scatter of the next).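

In this assay, methoxy in place of hydrogen on an aromatic carbon, on the six-membered aromatic ring of carbon only that is part of the fused system, gives a number 9.1 percentage points lower from compound 1 to compound 3 (within the scatter) and so does not separate compound 3 from compound 1. Within the data shown here, this is the first reading at this position, and it shows that the shared core accepts methoxy there, with its additional heavy atoms and hydrogen-bond acceptor, without a step beyond the scatter. Compound 1, compound 2 and compound 3 therefore cannot be ranked by this assay, since each stands within the scatter of the next. Nothing available on these compounds accounts for the size of this step.

The compounds shown leave open whether a hydroxyl, an amine or a longer chain such as butoxy at this same aromatic carbon would also stay within the scatter of compound 1 or would move the number beyond it. They also leave open whether methoxy on the other carbons of that ring would read the same way.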